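The compounds below may be only part of what the source reports. "The series", "measured", "known", "first", "only" and "open" are said of these compounds alone.

Compound 1 `O=C(CSC(=S)N[C@H]1CCOC1=O)Nc1ccccc1`: in a functional assay on EC9706 cells (Homo sapiens) for cytotoxicity, read by MTT assay, with a stated time of 72 h (a higher number here means a weaker inhibitor, a lower number a stronger inhibitor), compound 1 gives > 128000 nM, which is a limit of the assay.
Compound 2 `Cc1ccc(NC(=O)CSC(=S)N[C@H]2CCOC2=O)cc1`: in this assay compound 2 gives 93900 nM.
Compound 3 `CC(=O)c1ccc(NC(=O)CSC(=S)N[C@H]2CCOC2=O)cc1`: in this assay compound 3 gives > 128000 nM, again a limit of the assay.

Compound 3 thus stands at the limit of > 128000 nM in this assay, at which 2 of the 3 values shown sit; no number for it is known. Compound 4 `CCOC(=O)c1ccc(NC(=O)CSC(=S)N[C@H]2CCOC2=O)cc1` differs from compound 3 by ethoxy in place of methyl on a carbonyl carbon. For the measured compounds named here, the steps that bear on this point are a step that the two limits leave unreadable from compound 1 to compound 3 and an at least 1.3-fold higher number from compound 2 to compound 3 (0.13 log units; that floor lies within the scatter), and neither gives a readable size, so nothing here sizes a change on that carbonyl carbon. Starting from a limit, the expected step in this assay is a number no higher from compound 3 to compound 4 (the limit leaves the size open), none beyond the scatter, with a limit again the likeliest outcome. Compound 4 is therefore estimated at 128000 nM, range 50000 nM to 320000 nM.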

Compound 4, half-maximal inhibitory concentration: 112000 nM
Estimate against measurement, compound 4: 1.1-fold (0.06 log units) above, and the stated range covers the measured number.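

Ethoxy in place of methyl on the carbonyl carbon gives a measured number where acetyl gave only a limit, but the step (an at least 1.1-fold lower number from compound 3 to compound 4 (0.05 log units; that floor lies within the scatter)) has only a floor, within the scatter, in this assay. Against methyl and hydrogen on the aromatic carbon, ethoxycarbonyl likewise shows nothing beyond the scatter (a 1.2-fold higher number from compound 2 to compound 4 (0.08 log units; within the scatter)) and (an at least 1.1-fold lower number from compound 1 to compound 4 (0.05 log units; that floor lies within the scatter)). No change at this position yet gives a step beyond the scatter.

From the compounds shown here alone, whether an amine or a carboxylic acid on that aromatic carbon, or a longer chain in place of ethoxy, would give such a step remains open.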